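Swapping methyl for trifluoromethyl on the amide aryl

This account rests on a few compounds, and the source may have more. Where it says the series, first, only, none or still open, it means among the compounds named here.

Three measured compounds share one core and differ only in the group on the amide nitrogen. Compound 1 `COc1ccc(-n2nc(C(N)=O)nc2-c2cc(OC)c(OC)c(OC)c2)cc1` gives 40% in a functional assay on the whole organism for inhibition, with Rattus norvegicus as the target, read by paw edema, with stated times of 30 min and 1 h, at a dose of 0.28 mmol/kg by the oral route; a higher number here means more inhibition at the dose given (going by the name of the read-out), a lower number less inhibition. Compound 2 `CCNC(=O)c1nc(-c2cc(OC)c(OC)c(OC)c2)n(-c2ccc(OC)cc2)n1` gives 60% in this assay, and compound 3 `COc1ccc(-n2nc(C(=O)Nc3ccc(C)cc3)nc2-c2cc(OC)c(OC)c(OC)c2)cc1` gives 38% in this assay. The number of compound 3 is the lowest of the three, but its gap to compound 1 lies within the scatter, so those two cannot be ordered; only the gap to compound 2, a number 22 percentage points lower from compound 2 to compound 3 (beyond the scatter), is beyond it. The step of a number 2 percentage points lower from compound 1 to compound 3 (within the scatter) likewise stayed within the scatter.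

Compound 4 `COc1ccc(-n2nc(C(=O)Nc3ccc(C(F)(F)F)cc3)nc2-c2cc(OC)c(OC)c(OC)c2)cc1` differs from compound 3 in one place: trifluoromethyl in place of methyl on an aromatic carbon. Within the data shown here, none of the measured steps alters a group on the six-membered aromatic ring of carbon only; all of them exchange the whole group on the amide nitrogen, so no direct guide exists for this change. The step of no change at the digits printed from compound 3 to compound 4 (within the scatter) is therefore expected to stay within the scatter. Compound 4 is estimated at 38% in this assay, with a range from 20% to 58%.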

Compound 4, a percentage reported as inhibition, in the whole organism at one dose (the size of the read-out at that dose, not a potency): 48%
The estimate for compound 4 lay 10 percentage points below the measured number; low and high end bracket the measured number.
By their numbers in this assay, from the lowest: compounds 3, 1 and 4 (each within the scatter of the next); then compound 2.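

Among the compounds shown, this is the only step that alters a substituent on the aromatic ring of the amide group rather than replacing the whole group on the amide nitrogen. In this assay, the step is a number 10 percentage points higher from compound 3 to compound 4 (within the scatter), so the data do not separate methyl from trifluoromethyl at this position. Compound 4 also cannot be told apart from the plain amide, with a number 8 percentage points higher from compound 1 to compound 4 (within the scatter), whereas the ethyl amide stays clearly ahead of it, with a number 12 percentage points lower from compound 2 to compound 4 (beyond the scatter).

No measurement available here bears on what lies behind these numbers. On these data alone, it remains open whether an amine or a carboxylic acid on this aromatic carbon, or a chain longer than ethyl on the amide nitrogen, would shift the inhibition beyond the scatter.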